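The compounds below may be only part of what the source reports. "The series", "measured", "known", "first", "only" and "open" are said of these compounds alone.

In an ADME assay on NIH3T3 cells (Mus musculus) for cytotoxicity, read by MTT assay, with a stated time of 24 h (on this read-out higher numbers stand for weaker inhibition and lower numbers for stronger inhibition), compound 2 `O=C(CSc1ncccn1)N/N=c1/scc(-c2ccccc2)n1-c1ccccc1` gives 107 ug/mL, the lower of the two numbers recorded, and compound 1 `O=C(CSc1nnnn1-c1ccccc1)N/N=c1/scc(-c2ccc(Br)cc2)n1-c1ccccc1` gives 433 ug/mL, a gap beyond the scatter. Compound 3 `O=C(CSc1nnnn1-c1ccccc1)N/N=c1/scc(-c2ccccc2)n1-c1ccccc1` carries 1-phenyl-1H-tetrazol-5-yl in place of pyrimidin-2-yl on a sulfur. For the measured compounds named here, compound 1 shares this group but also differs from compound 3 in its bromine, so no single step isolates the change. Still, with compound 1 at 433 ug/mL, the step for compound 3 is expected to run toward weaker inhibition, roughly a 2.3-fold higher number from compound 2 to compound 3 (0.37 log units; beyond the scatter). Compound 3 is therefore estimated at 250 ug/mL, with a range from 100 ug/mL to 550 ug/mL.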

Compound 3, half-maximal inhibitory concentration: 417 ug/mL
The estimate for compound 3 lay 1.7-fold (0.22 log units) below the measured number; the range from low to high includes it.
By their numbers in this assay, from the lowest: compound 2; then compounds 3 and 1 (each within the scatter of the next).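

In this assay, the change on the sulfur can now be read on its own: 1-phenyl-1H-tetrazol-5-yl in place of pyrimidin-2-yl gives a 3.9-fold higher number from compound 2 to compound 3 (0.59 log units; beyond the scatter) and so goes with weaker inhibition. Hydrogen in place of bromo on an aromatic carbon gives a 1.0-fold lower number from compound 1 to compound 3 (0.02 log units; within the scatter), so the bromine makes no difference beyond the scatter with the tetrazolyl group present. Nothing measured here explains either step.

Still open, as far as these compounds go, is whether an amine or a longer chain on the sulfur would shift the number further. From the compounds shown here alone, whether methoxy on that aromatic carbon would also leave it within the scatter remains unknown.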